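Methoxyphenyl isomers on the shared core

A few compounds are considered here, and "the series" means these few. Any claim that something is new, unique, unknown or untested is made for them only; others in the source may bear on it.

Compound 2 `COc1cccc(-c2sc(N)c(C(=O)c3ccc(Cl)cc3)c2CC(C)(C)C)c1` stands in an assay on CHO cells for displacement of a labelled ligand from adenosine receptor A1 (Homo sapiens), read by scintillation counting, tested at 10 uM (on this read-out lower numbers stand for less inhibition and higher numbers for more inhibition at the one concentration tested (going by the name of the read-out)), at 1%, level with compound 1 `CC(C)(C)Cc1c(-c2cccnc2)sc(N)c1C(=O)c1ccc(Cl)cc1`, which in this assay gives 1%. The step of no change at the digits printed from compound 1 to compound 2 (within the scatter) was flat. Compound 3 `COc1ccccc1-c1sc(N)c(C(=O)c2ccc(Cl)cc2)c1CC(C)(C)C` differs from compound 2 by 2-methoxyphenyl in place of 3-methoxyphenyl on an aromatic carbon. For the measured compounds named here, no measured step moves a methoxy group around its ring; the one step in hand at this carbon, 3-methoxyphenyl in place of pyridin-3-yl, left the read-out unchanged. The expected step is therefore a number 1 percentage points higher from compound 2 to compound 3 (within the scatter), nothing beyond the scatter. Compound 3 is estimated at 2%, with a range from 0% to 15%.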

Compound 3, a percentage reported as inhibition, at one concentration (the size of the read-out at that concentration, not a potency): 1%
Beside the measured number, compound 3's estimate is 1 percentage points above it; the measured number falls inside the stated range.
By their numbers in this assay, from the lowest: compounds 1, 2 and 3 (each within the scatter of the next).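

For the compounds shown here, the step from the 3-methoxyphenyl to the 2-methoxyphenyl isomer gives no change at the digits printed from compound 2 to compound 3 (within the scatter) in this assay and is the first reading of a methoxy shift on the aromatic carbon next to the ring sulfur. Set against the pyridin-3-yl group, the 2-methoxyphenyl group gives no change at the digits printed from compound 1 to compound 3 (within the scatter) as well, so both methoxyphenyl isomers read level with the pyridine here. No evidence at hand bears on this flat result.

Open, going by these compounds, is whether 4-methoxyphenyl would also read level. Also open, on these data alone, is whether a carboxylic acid or an aminomethyl group on this phenyl ring would move the read-out beyond the scatter.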